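Changes on the ring nitrogen of the shared core

The source may hold more compounds than are shown below. What is called first, only, known or untested is meant among the compounds shown, and "the series" means these compounds.

Measured so far:
- compound 1 `O=C(/C(=N/O)Nc1ccc(F)c(Br)c1)C1CCN(C(=O)NCc2ccccc2)CC1`: 43 nM in an assay for inhibition of Indoleamine 2,3-dioxygenase 1 (Homo sapiens), with a stated time of 1 h; on this read-out lower numbers stand for stronger inhibition and higher numbers for weaker inhibition
- compound 2 `O=C(/C(=N/O)Nc1ccc(F)c(Br)c1)C1CCN(S(=O)(=O)Nc2ccccc2)CC1`: 98 nM in this assay

For the measured compounds named here, compound 2 holds the higher of the two numbers; its only neighbour is compound 1, separated from it by a 2.3-fold higher number from compound 1 to compound 2 (0.36 log units; beyond the scatter). Compound 3 `O=C(/C(=N/O)Nc1ccc(F)c(Br)c1)C1CCN(C(=O)c2ccccc2)CC1` is the next variation at the same place: benzoyl in place of phenylsulfamoyl on an amine nitrogen in a ring. Going by the values given here, the single measured step is that modest one at this position, and it does not involve benzoyl, so it gives only the scale of change to expect; the entering group shares a carbonyl on the ring nitrogen with the group of compound 1. A small step towards lower numbers, not beyond the scatter, is expected, a 1.8-fold lower number from compound 2 to compound 3 (0.25 log units; within the scatter). For compound 3 the estimate in this assay is 55 nM, between 20 nM and 150 nM.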

Compound 3, half-maximal inhibitory concentration: 106 nM
Compound 3: middle estimate off by 1.9-fold (0.28 log units), on the low side; low and high end bracket the measured number.
By their numbers in this assay, from the lowest: compound 1; then compounds 2 and 3 (each within the scatter of the next).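

In this assay, the carbonyl on the ring nitrogen does not by itself match compound 1: phenyl in place of benzylamino on a carbonyl carbon gives a 2.5-fold higher number from compound 1 to compound 3 (0.39 log units; beyond the scatter). Benzoyl and phenylsulfamoyl are not separated at this position, with a 1.1-fold higher number from compound 2 to compound 3 (0.03 log units; within the scatter), so exchanging the carbonyl for the sulfonyl-bearing group makes no readable difference here. No measurement at hand explains either step.

Open, as far as these compounds go, is whether phenylacetyl, which keeps the longer chain but lacks the amide nitrogen, behaves like benzylamino on the carbonyl. A benzylsulfamoyl group would show whether the same extension also counts on the sulfamoyl side.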